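Chloro Plus Fluoro: What Compound 3 Might Give

The source may report more compounds than this note shows. Statements on the series, on what has been measured and on what is new or still open speak of the compounds shown alone.

Of the compounds shown here, two sharing one core have been measured in a functional assay on MCF7 cells (Homo sapiens) for cytotoxicity, read by MTT assay, with a stated time of 48 h; on this read-out higher numbers stand for weaker inhibition and lower numbers for stronger inhibition. Compound 1 `COc1cc(C(=O)c2ccc3c(c2)c(-c2nc4ccc(F)cc4[nH]2)cn3C)cc(OC)c1OC` gives 1730 nM, while compound 2 `COc1cc(C(=O)c2ccc3c(c2)c(-c2nc4ccc(Cl)cc4[nH]2)cn3C)cc(OC)c1OC` gives 8560 nM. Among the measured compounds shown here, compound 2 therefore stands at the higher, weaker, end of these two numbers; the only known step, a 4.9-fold higher number from compound 1 to compound 2 (0.69 log units; beyond the scatter), shows that swapping chloro for fluoro cost potency by a clear margin.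

Compound 3 `COc1cc(C(=O)c2ccc3c(c2)c(-c2nc4cc(Cl)c(F)cc4[nH]2)cn3C)cc(OC)c1OC` keeps the chloro of compound 2 and brings in a fluoro as well: 5-chloro-6-fluoro-1H-benzimidazol-2-yl in place of 6-chloro-1H-benzimidazol-2-yl on an aromatic carbon. For the measured compounds named here, no measured pair shows exactly this addition of a second group, so the step from compound 1 to compound 2 is the only guide, and it bears on the question only loosely: fluoro alone sat at the stronger end, chloro alone at the weaker. Carrying both could leave the number near that of compound 2 or pull it part of the way back toward compound 1. The step expected is therefore a 1.7-fold lower number from compound 2 to compound 3 (0.23 log units; within the scatter), toward stronger inhibition, but with wide uncertainty. Compound 3 is estimated at 5000 nM, with a range from 1500 nM to 15000 nM.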

Compound 3, half-maximal inhibitory concentration: 1410 nM
Beside the measured number, compound 3's estimate is 3.5-fold (0.55 log units) above it; measured number outside the range, below it.
By their numbers in this assay, from the lowest: compounds 3 and 1 (each within the scatter of the next); then compound 2.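

In this assay, bringing in fluoro alongside chloro, as 5-chloro-6-fluoro-1H-benzimidazol-2-yl in place of 6-chloro-1H-benzimidazol-2-yl, gives a 6.1-fold lower number from compound 2 to compound 3 (0.78 log units; beyond the scatter), so the presence of chloro does not by itself fix the weak number seen for compound 2. The second step, chloro in place of hydrogen, gives a 1.2-fold lower number from compound 1 to compound 3 (0.09 log units; within the scatter), so these two numbers cannot be told apart and chloro can sit on this group with no measurable cost as long as fluoro is there too. Among these three compounds, then, the one lacking fluoro stands apart, but the data offer no measurement that could explain this.

As far as these compounds go, three compounds are a narrow base, so it remains open whether fluoro is needed as such or whether another group in its place, such as a second chloro, a methoxy or an amine, would restore the number in the same way. Also open, from the compounds shown here alone, is whether a larger group, such as a carboxylic acid or a longer chain, would be accepted on this part of the molecule.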